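Aryl group entering the shared core: outlook for compound 4

This account rests on a few compounds, and the source may have more. Where it says the series, first, only, none or still open, it means among the compounds named here.

compound 1 `CC(=O)c1cc2ccc(OCCCn3cc(CNC(=O)CCCCC4CCSS4)nn3)cc2oc1=O`: 40.7%
compound 2 `O=C(CCCCC1CCSS1)NCc1cn(CCCOc2ccc3cc(-c4ccc(Cl)cc4)c(=O)oc3c2)nn1`: 79.4%
compound 3 `O=C(CCCCC1CCSS1)NCc1cn(CCCCOc2ccc3ccc(=O)oc3c2)nn1`: 75.8%

In a functional assay on PC-12 cells (Rattus norvegicus) for cytotoxicity, read by MTT assay, with stated times of 3 h and 2 h, tested at 50 uM (a higher number here means a stronger effect of the compound at the concentration tested, a lower number a weaker effect), compound 1 gives 40.7%, compound 2 gives 79.4% and compound 3 gives 75.8%. Compound 3 stands second of the three numbers; its gap to compound 2 lies within the scatter, its gap to compound 1 beyond it. Compound 4 `O=C(CCCCC1CCSS1)NCc1cn(CCCCOc2ccc3cc(-c4ccccc4)c(=O)oc3c2)nn1` differs from compound 3 by phenyl in place of hydrogen on an aromatic carbon. Going by the values given here, one measured step touches the same place on the core: a number 38.7 percentage points higher from compound 1 to compound 2 (beyond the scatter), where 4-chlorophenyl entered in place of acetyl. Among the compounds with values here, compound 3 already carries hydrogen there and sits close to compound 2, so no step of that size is expected here; a small change is expected, a number 4.2 percentage points higher from compound 3 to compound 4 (within the scatter). Compound 4 is therefore estimated at 80%, in the range 66% to 92%.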

Compound 4, a percentage reported as activity, at one concentration (the size of the read-out at that concentration, not a potency): 20.5%
Estimate against measurement, compound 4: 59.5 percentage points above; measured number below the stated range.
By their numbers in this assay, from the lowest: compound 4; then compound 1; then compounds 3 and 2 (each within the scatter of the next).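

In this assay, an aryl group at this position does not by itself raise the number: phenyl in place of hydrogen gives a number 55.3 percentage points lower from compound 3 to compound 4 (beyond the scatter), the opposite direction to a number 38.7 percentage points higher from compound 1 to compound 2 (beyond the scatter), where 4-chlorophenyl replaced acetyl. The two steps start from different groups on different chains, so the direction of the earlier step does not carry over to this one. Nothing available explains the fall.

No pair shown separates the effect of the chlorine on the phenyl from that of the chain. Going by these compounds, how methyl, or a phenyl bearing an amine, would read at this position stays open.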